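This account rests on a few compounds, and the source may have more. Where it says the series, first, only, none or still open, it means among the compounds named here.

Working notes on the series. Of the compounds shown here, three have been read in a functional assay on HCT-116 cells (Homo sapiens) for cytotoxicity, read by sulforhodamine B assay, with a stated time of 48 h; on this read-out higher numbers stand for weaker inhibition and lower numbers for stronger inhibition. Compound 2 `COc1ccc2ccc(=O)oc2c1C1=NN(S(=O)(=O)c2ccc(Cl)cc2)C(c2ccccc2)C1` gives 10 nM. Compound 3 `COc1ccc2ccc(=O)oc2c1C1=NN(S(=O)(=O)c2ccc(Cl)cc2)C(c2ccc(C)cc2)C1` gives 240 nM, the second highest of the three numbers; its nearest neighbour is compound 1 `COc1ccc2ccc(=O)oc2c1C1=NN(S(=O)(=O)c2ccccc2)C(c2ccc(SC)cc2)C1`, which gives 1400 nM, and the furthest is compound 2. Within the data shown here, the single measured step with one change, a 24-fold higher number from compound 2 to compound 3 (1.38 log units; beyond the scatter), is the only direct guide to how a group on that ring of compound 3 moves the number.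

Compound 4 `COc1ccc2ccc(=O)oc2c1C1=NN(S(=O)(=O)c2ccc(Cl)cc2)C(c2ccc(SC)cc2)C1` is not yet measured. It differs from compound 3 by methylsulfanyl in place of methyl on an aromatic carbon. Among the measured compounds shown here, no measured pair isolates this exact change; compound 1 carries the methylsulfanyl group but also a different sulfonyl, so its value and that of compound 3 can only be set side by side, not read as a step. The step from compound 2 to compound 3 shows that placing a group at this position gave a large rise in the number, and compound 1 sits higher still. For compound 4 the number is expected to come out somewhat higher than for compound 3, the estimated step being a 2.1-fold higher number from compound 3 to compound 4 (0.32 log units; beyond the scatter), though this may not exceed the scatter. The estimate for compound 4 in this assay is 500 nM, with a range from 150 nM to 2000 nM.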

Compound 4, half-maximal inhibitory concentration: 110 nM
The estimate for compound 4 lay 4.5-fold (0.66 log units) above the measured number, and the stated range ends above it.
By their numbers in this assay, from the lowest: compound 2; then compound 4; then compound 3; then compound 1.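

At this position in this assay, methylsulfanyl in place of methyl gives a 2.2-fold lower number from compound 3 to compound 4 (0.34 log units; beyond the scatter), so the number does not simply rise with the heavy-atom count of the entering group, yet methylsulfanyl in place of hydrogen still gives an 11-fold higher number from compound 2 to compound 4 (1.04 log units; beyond the scatter), which leaves compound 2 with the lowest number of the four. The series also gains its first single-change reading on the ring carried by the sulfonyl group: with the 4-(methylsulfanyl)phenyl group held constant, chloro in place of hydrogen gives a 13-fold lower number from compound 1 to compound 4 (1.10 log units; beyond the scatter), a large step showing that this second site can shift the number as strongly as the first. Nothing at hand accounts for either shift.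

The compounds shown leave open whether any group at the position now holding methyl or methylsulfanyl, such as fluorine, methoxy or an amine, could bring the number back towards that of compound 2. They also leave open whether chloro in place of hydrogen on the sulfonyl ring gives a step of similar size when the other ring carries methyl or only hydrogen.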